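Anilino replaces ethylamino on the chlorobenzyloxy coumarin

The compounds below may be only part of what the source reports. "The series", "measured", "known", "first", "only" and "open" are said of these compounds alone.

Among the compounds with values here, compound 2 `CCNc1cc(=O)oc2cc(OCc3cccc(Cl)c3)ccc12` gives the lowest of the two numbers so far in an assay on isolated protein (strain Sprague-Dawley) for inhibition of Amine oxidase [flavin-containing] B (Rattus norvegicus), read by spectrophotometry, with a stated time of 5 min (on this read-out lower numbers stand for stronger inhibition and higher numbers for weaker inhibition), at 28.2 nM, with compound 1 `CCOc1cc(=O)oc2cc(OCc3cccc(Cl)c3)ccc12` at 115 nM as its nearest neighbour, which shows a 4.1-fold lower number from compound 1 to compound 2 (0.61 log units; beyond the scatter). Compound 3 `O=c1cc(Nc2ccccc2)c2ccc(OCc3cccc(Cl)c3)cc2o1` differs from compound 2 by phenyl in place of ethyl on a nitrogen on an aromatic ring. Within the data shown here, no measured step touches this change; the only step known concerns the link to the core, not the group on the nitrogen. The estimate for compound 3 is therefore a step of a 2.1-fold higher number from compound 2 to compound 3 (0.33 log units; beyond the scatter), wider in doubt than the scatter. Compound 3 is expected to give 60 nM, between 12 nM and 300 nM.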

Compound 3, half-maximal inhibitory concentration: 9770 nM
For compound 3 the middle estimate is 160-fold (2.21 log units) below the measured one; the whole stated range lies below it.
By their numbers in this assay, from the lowest: compound 2; then compound 1; then compound 3.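

In this assay, the position proves far less forgiving than the earlier ethoxy and ethylamino pair suggested: the group on the nitrogen, not only the link to the core, decides the result, with phenyl in place of ethyl giving the largest change so far (a 350-fold higher number from compound 2 to compound 3 (2.54 log units; beyond the scatter)). Anilino also falls well behind ethoxy (an 85-fold higher number from compound 1 to compound 3 (1.93 log units; beyond the scatter)). No evidence here accounts for this drop. The compounds shown leave open whether any ring on the nitrogen has this outcome or only a phenyl joined directly to it. A benzylamino or cyclohexylamino group, or a longer chain such as propylamino, would separate those readings.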